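Trading a Carbamoyl Arm for a Benzyl Group

The compounds below may be only part of what the source reports. "The series", "measured", "known", "first", "only" and "open" are said of these compounds alone.

Compound 1 `COc1ccc(-c2cnc3nc(N)nc(N4CCN(C(=O)NCc5ccc(F)cc5)CC4)c3n2)cc1OC` was tested in a functional assay on cells (T-cell, Homo sapiens) for inhibition (a lower number here means a stronger inhibitor, a higher number a weaker inhibitor), where compound 1 gives 37 nM, the lowest of the two numbers recorded. Compound 2 `CC(C)Oc1nc(N)nc2ncc(-c3ccc(F)c(F)c3)nc12` in this assay gives 10000 nM, a much higher number that stands well beyond the scatter of the method. Compound 3 `CCOc1nc(N)nc2ncc(-c3ccc(Cl)c(Cl)c3)nc12` reaches only a limit of the assay in this assay, > 10000 nM, and that limit is the one described in the limit of > 10000 nM in this assay, at which 1 of the 3 values shown sits. Among the measured compounds shown here, compounds 2 and 3 differ from compound 1 in more than one place, so no single step between either of them and compound 1 can be counted.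

Compound 4 `COc1ccc(-c2cnc3nc(N)nc(N4CCN(Cc5ccccc5)CC4)c3n2)cc1OC` has not yet been measured. Its structure differs from compound 1 in one place: benzyl in place of (4-fluorobenzyl)carbamoyl on an amine nitrogen in a ring. The carbamoyl arm departs together with its hydrogen-bond donor and acceptor, and the amine nitrogen in the ring then carries only the benzyl group. For the measured compounds named here, no measured pair shows this step, so its size can only be estimated. Compound 4 is expected to be somewhat weaker than compound 1, with the step of a 4.1-fold higher number from compound 1 to compound 4 (0.61 log units; beyond the scatter) judged likely to fall beyond the scatter. The estimate for compound 4 in this assay is 150 nM, within a range from 30 nM to 800 nM.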

Compound 4, half-maximal inhibitory concentration: 900 nM
For compound 4 the middle estimate is 6.0-fold (0.78 log units) below the measured one; the measured number lies above the stated range.
By their numbers in this assay, from the lowest: compound 1; then compound 4; then compound 2.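

In this assay, the group on the amine nitrogen in a ring proves to matter a great deal: with the rest of the structure unchanged, benzyl in place of (4-fluorobenzyl)carbamoyl gives a 24-fold higher number from compound 1 to compound 4 (1.39 log units; beyond the scatter), a large step beyond the scatter. Among the compounds shown here, this is the first comparison here between compounds that differ in one place, and it shows that this position is sensitive to the group it carries, although compound 4 still gives a measurable 900 nM rather than a limit of the assay. The change removes the carbonyl, the amide hydrogen and the fluorine in one step, and nothing measured here assigns the size of that step to any one of these parts.

The compounds shown leave open how a 4-fluorobenzyl group set directly on that nitrogen, or a benzylcarbamoyl group without the fluorine, would stand in this assay, either of which would separate these parts. Also open, from the compounds shown here alone, is whether a small acyl group such as acetyl, or a sulfonyl link to the same benzyl group, would bring the number back towards that of compound 1.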